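Swapping the Aryl Ring on a Nitrooxy Amide Chalcone

The compounds below may be only part of what the source reports. "The series", "measured", "known", "first", "only" and "open" are said of these compounds alone.

Of the compounds shown here, three have been tested in a functional assay on the whole organism (strain albino) for inhibition, with Rattus norvegicus as the target, read by paw edema, with stated times of 30 min and 2 h, at a dose of 100 mg/kg by the oral route; on this read-out lower numbers stand for less inhibition and higher numbers for more inhibition at the one dose given (going by the name of the read-out). Compound 1 `COc1ccc(/C=C/C(=O)c2ccc(NC(=O)C(C)Br)cc2)cc1` gives 40%. Compound 2 `CC(Br)C(=O)Nc1ccc(C(=O)/C=C/c2ccco2)cc1` gives 37%; it differs from compound 1 by furan-2-yl in place of 4-methoxyphenyl on a double-bonded chain carbon bound to a double-bonded chain carbon, and this change made a number 3 percentage points lower from compound 1 to compound 2 (within the scatter). Compound 3 `COc1ccc(/C=C/C(=O)c2ccc(NC(=O)C(C)O[N+](=O)[O-])cc2)cc1` shares the core of compound 1 but carries the difference (nitrooxy in place of bromo on a saturated chain carbon bound to a carbonyl carbon and a saturated chain carbon); in this assay compound 3 gives 46%, a step of a number 6 percentage points higher from compound 1 to compound 3 (within the scatter). All three numbers lie within the usual scatter of one another, so none of them can be called stronger or weaker than the others.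

Compound 4 `CC(O[N+](=O)[O-])C(=O)Nc1ccc(C(=O)/C=C/c2ccco2)cc1` has not yet been measured. It differs from compound 3 by furan-2-yl in place of 4-methoxyphenyl on a double-bonded chain carbon bound to a double-bonded chain carbon, which is the same change that turned compound 1 into compound 2, made at a place described in the same words. Compound 4 is expected to give 43% in this assay, most likely between 31% and 55%. The step expected here is a number 3 percentage points lower from compound 3 to compound 4 (within the scatter). That expectation rests on the earlier step of a number 3 percentage points lower from compound 1 to compound 2 (within the scatter) and on compound 3 at 46% as the starting point.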

Compound 4, a percentage reported as inhibition, in the whole organism at one dose (the size of the read-out at that dose, not a potency): 48%
For compound 4 the middle estimate is 5 percentage points below the measured one; the measured number falls inside the stated range.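

In this assay, furan-2-yl in place of 4-methoxyphenyl gives a number 2 percentage points higher from compound 3 to compound 4 (within the scatter), and this agrees with the same swap made earlier: the same change on two cores in this assay, a number 3 percentage points lower (within the scatter) from compound 1 to compound 2 and a number 2 percentage points higher (within the scatter) from compound 3 to compound 4, 5 percentage points apart, within the scatter of two such steps. Nitrooxy in place of bromo gives a number 11 percentage points higher from compound 2 to compound 4 (beyond the scatter), and this too can be set beside its earlier counterpart: the same change on two cores in this assay, a number 6 percentage points higher (within the scatter) from compound 1 to compound 3 and a number 11 percentage points higher (beyond the scatter) from compound 2 to compound 4, 5 percentage points apart, within the scatter of two such steps. Each change therefore behaves alike on the two cores as far as this read-out can tell, but two cores at one dose do not prove that the steps are identical or that they would hold on a third core, and the nitrooxy step passes the scatter only in the furan-2-yl pair, not in the 4-methoxyphenyl pair.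

As far as these compounds go, it remains open whether a thiophene ring in place of furan-2-yl, or an amine or a carboxylic acid in place of nitrooxy, would fit the same picture. Also open, from the compounds shown here alone, is how these steps would look at other doses, since a single dose gives the size of an effect and not a potency.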